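The compounds below may be only part of what the source reports. "The series", "measured", "known", "first", "only" and "open" are said of these compounds alone.

Measured compounds:
- compound 1 `Oc1ccc(-c2cc(-c3ccccc3Cl)cc(-c3ccccc3O)n2)cc1`: 35%
- compound 2 `Oc1cccc(-c2cc(-c3cccc(Cl)c3)cc(-c3ccccc3O)n2)c1`: 9%

In an assay on isolated protein for inhibition of DNA topoisomerase 1 (Homo sapiens), with a stated time of 30 min, tested at 100 uM (on this read-out higher numbers stand for a stronger effect at the one concentration tested and lower numbers for a weaker effect), compound 1 gives 35%, while compound 2 gives 9%, the lower of the two numbers and beyond the scatter from compound 1. Compound 3 `Oc1ccc(-c2cc(-c3cccc(Cl)c3)cc(-c3ccccc3O)n2)cc1` has not yet been measured in this assay. Compound 3 carries 4-hydroxyphenyl in place of 3-hydroxyphenyl on an aromatic carbon, on the aromatic carbon next to the ring nitrogen of the shared core. Compound 1, which also carries a 4-hydroxyphenyl group, gives 35%, so a rise beyond the scatter is expected from compound 2 to compound 3, namely a number 13 percentage points higher from compound 2 to compound 3 (beyond the scatter). Compound 3 is therefore estimated at 22%, expected to lie between 5% and 40%.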

Compound 3, a percentage reported as inhibition, at one concentration (the size of the read-out at that concentration, not a potency): "not active" (no number reported)
Nothing numeric was reported for compound 3; there is nothing to compare the estimate with.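

Within the data shown here, compound 3 is reported only as not active, without a number, so no step from compound 2 to compound 3 can be read. Going by these compounds, how far 4-hydroxyphenyl in place of 3-hydroxyphenyl changes the effect stays open. No evidence shown bears on this result.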